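Swapping nitro for chloro on a triazolothiadiazine aryl ring

This account rests on a few compounds, and the source may have more. Where it says the series, first, only, none or still open, it means among the compounds named here.

Of the compounds shown here, two of a shared core have been measured in a functional assay on HCT-116 cells (Homo sapiens) for inhibition, read by sulforhodamine B assay, with a stated time of 72 h; on this read-out higher numbers stand for weaker inhibition and lower numbers for stronger inhibition. Compound 1, `COc1ccc2cc(C(C)c3nnc4n3N=C(c3ccc([N+](=O)[O-])cc3)CS4)ccc2c1`, gives 15100 nM in this assay. Compound 2, `CC(c1ccc(-c2ccccc2)c(F)c1)c1nnc2n1N=C(c1ccccc1)CS2`, gives 9700 nM. Of the two numbers, compound 1 carries the higher one, but the gap to compound 2 is within the usual scatter of repeated measurements, so the two cannot be told apart on these data alone. For the measured compounds named here, no step between measured compounds that differ in a single place is available, so the effect of any one change is so far unknown.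

Compound 3, `COc1ccc2cc(C(C)c3nnc4n3N=C(c3ccc(Cl)cc3)CS4)ccc2c1`, is not yet measured. It differs from compound 1 in one place: chloro in place of nitro on an aromatic carbon. The aryl group that carries this change stays otherwise unchanged, and the rest of the core is kept.

With nothing in the measured pair to anchor the swap, the expected step in this assay from compound 1 to compound 3 is small, a 1.3-fold lower number from compound 1 to compound 3 (0.10 log units; within the scatter), and may well fall within the scatter in either direction. Compound 3 is therefore estimated at 12000 nM in this assay, with a range from 4000 nM to 40000 nM.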

Compound 3, half-maximal inhibitory concentration: 8800 nM
Compound 3: middle estimate off by 1.4-fold (0.13 log units), on the high side, within the range that was stated.
By their numbers in this assay, from the lowest: compounds 3, 2 and 1 (each within the scatter of the next).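

For the compounds shown here, this is the first step that can be read at a single place: in this assay, the change from 4-nitrophenyl to 4-chlorophenyl comes to a 1.7-fold lower number from compound 1 to compound 3 (0.23 log units; within the scatter), so the two compounds cannot be told apart. On this aromatic carbon, para to a large group, the 3 heavy atoms and 2 hydrogen-bond acceptors of nitro give way to the 1 heavy atom and 0 hydrogen-bond acceptors of chloro, and the read-out of this pair stays within the scatter. No independent measurement is available to explain this result.

The compounds shown leave open whether a group of another kind at this place, such as an amine or a carboxylic acid, would give a step beyond the scatter. Going by these compounds alone, with only this one pair, they also leave open whether chloro in place of nitro would read the same way with other groups elsewhere on the shared core, so nothing general can yet be said about this change.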